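Swapping an indolyl group for a tert-butylphenyl on a shared core

This account rests on a few compounds, and the source may have more. Where it says the series, first, only, none or still open, it means among the compounds named here.

Measured compounds:
compound 1, `COc1cc(-c2ccnc3cc(-c4ccc5cc[nH]c5c4)nn23)cc(OC)c1OC`: 23 nM
compound 2, `COc1cc(-c2ccnc3cc(-c4cn(C(=O)OC(C)(C)C)c5ccccc45)nn23)cc(OC)c1OC`: 268 nM
compound 3, `COc1cc(-c2ccnc3cc(-c4cccc5c4ccn5CO)nn23)cc(OC)c1OC`: 1070 nM

All three were tested in a functional assay on MCF7 cells (Homo sapiens) for inhibition, read by CCK-8 assay, with a stated time of 48 h; on this read-out lower numbers stand for stronger inhibition and higher numbers for weaker inhibition. Compound 1 holds the lowest number of the three, and both steps away from it lie beyond the usual scatter: compound 2 sits clearly higher, and compound 3 sits higher still. The three compounds share a core with a trimethoxyphenyl group and differ in the aromatic group attached at the other end of that core.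

Compound 4, `COc1cc(-c2ccnc3cc(-c4ccc(C(C)(C)C)cc4)nn23)cc(OC)c1OC`, has not yet been measured. It differs from compound 1 in one place: 4-(tert-butyl)phenyl in place of 1H-indol-6-yl on an aromatic carbon. Among the measured compounds shown here, no measured pair shows this exact change, so the size of the step can only be estimated. With compound 1 at 23 nM as the starting point, and with the two other measured compounds both weaker than compound 1, the expectation is that compound 4 is weaker too, by a step beyond the scatter, a 13-fold higher number from compound 1 to compound 4 (1.12 log units; beyond the scatter). On that basis compound 4 is estimated at 300 nM, within a range from 60 nM to 1500 nM.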

Compound 4, half-maximal inhibitory concentration: > 10000 nM
Compound 4: only a limit was reported (the forecaster's own chance of this, stated with the estimate: 5%); middle value at least 33-fold (1.52 log units) from the limit.
By their numbers in this assay, from the lowest: compound 1; then compound 2; then compound 3. At a limit, above all of these: compound 4.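

In this assay, among the compounds shown here, this place on the shared core proves far less tolerant than the earlier compounds could show: 4-(tert-butyl)phenyl in place of 1H-indol-6-yl gives an at least 430-fold higher number from compound 1 to compound 4 (2.63 log units; beyond the scatter). Compound 4 is reported only as a limit of the assay, > 10000 nM, and not as a number: the limit of > 10000 nM in this assay, at which 1 of the 4 values shown sits. For the compounds shown here, the single change removes the five-membered ring and its hydrogen-bond donor and also brings in the tert-butyl group, so the result cannot tell which of these matters.

From the compounds shown here alone, it remains open whether a plain phenyl group, or a phenyl carrying a hydroxyl or an amine instead of the tert-butyl, would restore a low number here. Going by these compounds, it is also open whether the indole's nitrogen hydrogen counts, which a methyl group on that nitrogen would test.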